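This account rests on a few compounds, and the source may have more. Where it says the series, first, only, none or still open, it means among the compounds named here.

Measured so far:
compound 1 `COc1ccc(CCCO/N=c2/ccn([C@@H]3O[C@H](COP(=O)(O)OP(=O)(O)OP(=O)(O)O)[C@@H](O)[C@H]3O)c(=O)[nH]2)cc1`, giving 277 nM in a functional assay on 1321-N1 cells for agonist activity at P2Y purinoceptor 6 (Homo sapiens), read by scintillation counting and inositol phosphate accumulation; on this read-out higher numbers stand for an effect only at larger amounts of compound and lower numbers for an effect already at smaller amounts
compound 2 `O=c1[nH]/c(=N\OCCCc2ccncc2)ccn1[C@@H]1O[C@H](COP(=O)(O)OP(=O)(O)OP(=O)(O)O)[C@@H](O)[C@H]1O`, giving 4280 nM

Compound 2 gives the highest of the two numbers in this assay; its nearest neighbour, compound 1, lies far lower. Compound 3 `O=c1[nH]/c(=N\OCCCc2ccsc2)ccn1[C@@H]1O[C@H](COP(=O)(O)OP(=O)(O)OP(=O)(O)O)[C@@H](O)[C@H]1O` differs from compound 2 by thiophen-3-yl in place of pyridin-4-yl on a saturated chain carbon, three bonds along the chain from an oxygen. For the measured compounds named here, the only measured step that bears on an exchange of this ring is a 15-fold higher number from compound 1 to compound 2 (1.19 log units; beyond the scatter), a large one. As far as these compounds go, a further exchange of the same ring could therefore move the number considerably in this assay, while the direction remains open. Compound 3 is expected to give about 1500 nM, within 300 nM to 7000 nM, an estimated step of a 2.9-fold lower number from compound 2 to compound 3 (0.46 log units; beyond the scatter).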

Compound 3, half-maximal effective concentration: 164 nM
Estimate against measurement, compound 3: 9.1-fold (0.96 log units) above; the whole stated range lies above it.
By their numbers in this assay, from the lowest: compounds 3 and 1 (each within the scatter of the next); then compound 2.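

Exchanging pyridin-4-yl for thiophen-3-yl at this position of the chain gives a 26-fold lower number from compound 2 to compound 3 (1.42 log units; beyond the scatter), so in this assay the number is highly sensitive to the ring carried here, and the earlier step now has a counterpart in the opposite direction. The five-membered ring also matches the 4-methoxyphenyl group, with a 1.7-fold lower number from compound 1 to compound 3 (0.23 log units; within the scatter), leaving compound 2 alone apart from the other two. Nothing available explains why the pyridin-4-yl compound stands apart. As far as these compounds go, how an unsubstituted phenyl ring, a furan ring or a longer chain would read here remains open.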